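Replacing methoxymethyl with a longer side chain on compound 1

The compounds below may be only part of what the source reports. "The series", "measured", "known", "first", "only" and "open" are said of these compounds alone.

Within the data shown here, compound 1 `COCc1ccc(-c2ccc3nnc(C(N)=O)c(N[C@@H](C)C4CCOCC4)c3c2)cn1` was tested in an assay on HT-29 cells for inhibition of Serine-protein kinase ATM (Homo sapiens), read by fluorescence, with a stated time of 1 h (a lower number here means a stronger inhibitor, a higher number a weaker inhibitor), and gives 140 nM, the second highest of the three numbers measured so far. Compound 2 `COCc1ccc(-c2ccc3nnc(C(N)=O)c(N[C@@H](C)c4nn(C)cc4C)c3c2)cn1` gives 44 nM. That is a 3.2-fold lower number from compound 1 to compound 2 (0.50 log units; beyond the scatter). Compound 3 `CNC(=O)c1nnc2ccc(-c3ccc(COC)nc3)cc2c1N[C@@H](C)C1CCOCC1` gives 330 nM. That is a 2.4-fold higher number from compound 1 to compound 3 (0.37 log units; beyond the scatter). Compound 4 `C[C@H](Nc1c(C(N)=O)nnc2ccc(-c3ccc(OCCCN4CCCC4)nc3)cc12)C1CCOCC1` differs from compound 1 by 3-(pyrrolidin-1-yl)propoxy in place of methoxymethyl on an aromatic carbon. Neither measured step touches this position: one changes the group on the saturated chain carbon, the other the amide-type nitrogen, so they give no direct guide to this exchange, and both were modest. The number for compound 4 is therefore expected to stay near that of compound 1, with the expected step of a 1.2-fold lower number from compound 1 to compound 4 (0.07 log units; within the scatter) inside the usual scatter. Compound 4 is estimated at 120 nM, in the range 40 nM to 400 nM.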

Compound 4, half-maximal inhibitory concentration: 1.8 nM
The estimate for compound 4 lay 67-fold (1.82 log units) above the measured number; the measured number lies below the stated range.
By their numbers in this assay, from the lowest: compound 4; then compound 2; then compound 1; then compound 3.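

Of the places changed so far, this aromatic carbon next to the ring nitrogen shows the largest response: 3-(pyrrolidin-1-yl)propoxy in place of methoxymethyl gives a 78-fold lower number from compound 1 to compound 4 (1.89 log units; beyond the scatter). The earlier steps shown here, a 3.2-fold lower number from compound 1 to compound 2 (0.50 log units; beyond the scatter) and a 2.4-fold higher number from compound 1 to compound 3 (0.37 log units; beyond the scatter), were modest by comparison, so this side chain matters far more than they suggested. No measurement here explains the drop.

Still open, from the compounds shown here alone, is which part of the new chain is responsible: a plain propoxy chain without the amine, or a piperidine in place of the pyrrolidine, would help separate the parts. Going by these compounds, whether the same exchange helps when the pyrazole of compound 2 is present also remains open.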